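Lactam ring size and solubility across two cores

The source may hold more compounds than are shown below. What is called first, only, known or untested is meant among the compounds shown, and "the series" means these compounds.

Measured so far in a physicochemical assay for solubility, at pH 7.4; on this read-out higher numbers stand for higher solubility and lower numbers for lower solubility:
compound 1, `C[C@]1(CS(=O)(=O)N2CC=C(C#Cc3cccc(N4CCCC4=O)c3)CC2)NC(=O)NC1=O`, gives 94000 nM
compound 2, `C[C@]1(CS(=O)(=O)N2CC=C(C#Cc3cccc(N4CCCCC4=O)c3)CC2)NC(=O)NC1=O`, gives 89000 nM
compound 3, `O=C1CCCN1c1cccc(C(=O)N(c2ncccc2Cl)[C@@H]2CCCNC2)c1`, gives 67000 nM

Compounds 1 and 2 share one core; compound 3 is built on another, and the difference between the two cores is not broken down here. Compound 1 and compound 2 differ in a single place: 2-oxopiperidin-1-yl in place of 2-oxopyrrolidin-1-yl on an aromatic carbon. The measured step is a 1.1-fold lower number from compound 1 to compound 2 (0.02 log units; within the scatter). Compound 3 lies nearest to compound 2 and furthest from compound 1, both gaps within the scatter, so the three values cannot be ordered on this assay.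

Compound 4, `O=C1CCCCN1c1cccc(C(=O)N(c2ncccc2Cl)[C@@H]2CCCNC2)c1`, is not yet measured. It stands to compound 3 as compound 2 stands to compound 1: 2-oxopiperidin-1-yl in place of 2-oxopyrrolidin-1-yl on an aromatic carbon. The place of the change is described in the same words for both pairs, so the change is the same one; among the compounds shown it occurs two times, once with a measurement.

The step expected in this assay is a 1.1-fold lower number from compound 3 to compound 4 (0.03 log units; within the scatter), set close to the earlier one, because a 1.1-fold lower number from compound 1 to compound 2 (0.02 log units; within the scatter) stayed within the scatter. The estimate for compound 4 in this assay is 63000 nM, with most repeats expected between 32000 nM and 125000 nM. It rests on one measured pair on a different core, so it is an expectation, not a pattern.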

Compound 4, solubility: > 973000 nM
Compound 4: no number, only a limit; the forecaster's own chance of this, stated with the estimate: 5%; at least 15-fold (1.18 log units) between middle value and limit.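

The same replacement, 2-oxopiperidin-1-yl in place of 2-oxopyrrolidin-1-yl on an aromatic carbon, gives a 1.1-fold lower number from compound 1 to compound 2 (0.02 log units; within the scatter) on the core of compound 1 and an at least 14-fold higher number from compound 3 to compound 4 (1.16 log units; beyond the scatter) on the core of compound 3, so in these two pairs the change does not carry over from one core to the other as a single size of step. Compound 4 gives > 973000 nM in this assay, which is a limit of the assay and not a number: the limit of > 973000 nM in this assay, at which 1 of the 4 values shown sits. With one pair on each core, the notes show that the step can differ between cores, but they do not show which feature of the core of compound 3 goes with the large step, how large that step really is, or whether it would recur on a further core.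

Still open, going by these compounds, is whether the step on the core of compound 3 belongs to the lactam ring size alone or would also appear with another group at the same place, such as a seven-membered lactam, an open-chain amide or a carboxylic acid. Also open, on these data alone, is which of the two pairs a third core would resemble, since two pairs cannot set a rule for the series.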